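The source may hold more compounds than are shown below. What is called first, only, known or untested is meant among the compounds shown, and "the series" means these compounds.

Compound 1 `CC1(c2ccccc2)CC(=O)N(CC(=O)N2CCN(c3ccc(Cl)cc3)CC2)C1=O`: "not active" (no number reported)
Compound 2 `CC1(c2ccccc2)CC(=O)N(CC(=O)N2CCN(c3ccccc3)CC2)C1=O`: "not active" (no number reported)
Compound 3 `COc1ccccc1N1CCN(C(=O)CN2C(=O)CC(C)(c3ccccc3)C2=O)CC1`: 300 mg/kg

Within the data shown here, in a functional assay on the whole organism (strain CD-1) with Mus musculus as the target, in the maximal electroshock model, with a stated time of 2 h (on this read-out lower numbers stand for an effect already at smaller amounts and higher numbers for an effect only at larger amounts of compound), compound 3 gives 300 mg/kg, the only number among the three measured compounds. Among the measured compounds shown here, compound 1 gave "not active" (no number reported) and compound 2 gave "not active" (no number reported), so no step between measured compounds can be counted. Compound 4 `CC1(c2ccccc2)CC(=O)N(CC(=O)N2CCN(c3cccc(Cl)c3Cl)CC2)C1=O` differs from compound 3 in one place: 2,3-dichlorophenyl in place of 2-methoxyphenyl on an amine nitrogen in a ring. The two entries without a number show that a change on this ring can leave the compound without effect at the doses tested. He therefore expects compound 4 either to report no number or a dose close to that of compound 3. His estimate for compound 4 is 300 mg/kg (range 100 mg/kg to 600 mg/kg), a step of no change at the digits printed from compound 3 to compound 4 (within the scatter) expected to be none beyond the scatter.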

Compound 4, minimum effective dose: "not active" (no number reported)
Compound 4 has no reported number here; the estimate stays without a comparison.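

Among these compounds, compound 4, like compound 1 and compound 2, has no number in this assay, so no step from compound 3 can be read. Nothing measured here bears on this result. The compounds shown leave open whether any aryl group on the ring nitrogen gives a lower dose than compound 3 does.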